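Fluorophenyl to chlorophenyl on the triazole nitrogen

A few compounds are considered here, and "the series" means these few. Any claim that something is new, unique, unknown or untested is made for them only; others in the source may bear on it.

Compound 1, `Cc1ccccc1-n1cc(-c2ccc(NS(=O)(=O)c3c[nH]c(=O)[nH]c3=O)cc2)nn1`, gives 14500 nM in a functional assay on HepG2 cells (Homo sapiens) for antiproliferative activity, read by MTT assay, with a stated time of 24 h; on this read-out lower numbers stand for stronger inhibition and higher numbers for weaker inhibition.
Compound 2, `O=c1[nH]cc(S(=O)(=O)Nc2ccc(-c3cn(-c4ccc(F)cc4)nn3)cc2)c(=O)[nH]1`, returns > 20000 nM in this assay, which is a limit of the assay and not a number.

Compound 2 therefore stands at the limit (the limit of > 20000 nM in this assay, at which 1 of the 2 values shown sits); its true value is not known beyond that. Among the compounds with values here, the only measured step is an at least 1.3-fold higher number from compound 1 to compound 2 (0.13 log units; that floor lies within the scatter). From the compounds shown here alone, it ends at a limit, so its real size is unknown.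

Compound 3, `O=c1[nH]cc(S(=O)(=O)Nc2ccc(-c3cn(-c4cccc(Cl)c4)nn3)cc2)c(=O)[nH]1`, differs from compound 2 by 3-chlorophenyl in place of 4-fluorophenyl on an aromatic nitrogen. Within the data shown here, no measured step exchanges one halogenated phenyl for another on this nitrogen, so the single measured step gives no direct guide. With compound 2 at the limit in this assay and compound 1 also weak, compound 3 is expected to remain weak, and no step beyond the scatter is expected in this assay; the step of a number no higher from compound 2 to compound 3 (the limit leaves the size open) is the estimated one. Compound 3 is estimated at 20000 nM in this assay, within 8000 nM to 50000 nM, with a real chance that only a limit is reported.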

Compound 3, half-maximal inhibitory concentration: 2020 nM
For compound 3 the middle estimate is 9.9-fold (1.00 log units) above the measured one, outside the stated range (below it).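

Exchanging 4-fluorophenyl for 3-chlorophenyl on the aromatic nitrogen gives an at least 9.9-fold lower number from compound 2 to compound 3 (0.99 log units; beyond the scatter) in this assay, which shows that this position can respond to the choice of aryl group, something the first two compounds could not show. Exchanging 2-methylphenyl for 3-chlorophenyl at the same place gives a 7.2-fold lower number from compound 1 to compound 3 (0.86 log units; beyond the scatter), so 3-chlorophenyl stands apart from both earlier groups, and the second step, unlike the first, has a measured size. Compound 2 gives a limit and not a number, so the first of these steps has only a floor: the limit of > 20000 nM in this assay, at which 1 of the 3 values shown sits.

The compounds shown leave open whether the identity of the halogen or its place on the phenyl ring carries the change, as 3-chlorophenyl differs from 4-fluorophenyl in both at once, and 4-chlorophenyl or 3-fluorophenyl would be needed to tell these apart. They also leave open whether the lower number is specific to chlorine or would extend to other groups at this place on the phenyl ring, such as bromine, methoxy or an amine.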